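The source may report more compounds than this note shows. Statements on the series, on what has been measured and on what is new or still open speak of the compounds shown alone.

Three compounds sharing one core have been run in a functional assay on NCI-H460 cells (Homo sapiens) for cytotoxicity, read by MTT assay, with a stated time of 72 h; a higher number here means a weaker inhibitor, a lower number a stronger inhibitor. Compound 1 `CCN(CC)Cc1ccc2nc(NC(=O)N/N=C3\C(=O)Nc4ccc(F)cc43)sc2c1` gives 1060 nM there. Compound 2 `CC1CCN(Cc2ccc3nc(NC(=O)N/N=C/c4cn(Cc5ccc(Cl)cc5Cl)c5ccccc45)sc3c2)CC1` gives 1660 nM. Compound 3 `Cc1ccc(Cn2cc(/C=N/NC(=O)Nc3nc4ccc(CN(C)C)cc4s3)c3ccccc32)cc1` gives 200 nM. Compound 2 stands at the high end of the three: its gap to compound 1 lies within the usual scatter, while its gap to compound 3 lies beyond it.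

Compound 4 `CC1CCN(Cc2ccc3nc(NC(=O)N/N=C/c4cn(Cc5ccccc5Cl)c5ccccc45)sc3c2)CC1` has not yet been measured. It differs from compound 2 in one place: hydrogen in place of chloro on an aromatic carbon. No measured pair differs in only this place, so nothing shown fixes how large a step this change makes on its own. Compound 3 gives a lower number than compound 2, but it also differs from compound 2 elsewhere, so that gap cannot be laid at this change alone. One therefore expects a small step in this assay for compound 4, likely none beyond the scatter, leaning if anything toward a lower number. For compound 4 the expected value is 1300 nM, with a range from 500 nM to 3500 nM. This amounts to an expected 1.3-fold lower number from compound 2 to compound 4 (0.11 log units; within the scatter).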

Compound 4, half-maximal inhibitory concentration: 1080 nM
Compound 4: middle estimate off by 1.2-fold (0.08 log units), on the high side; the measured number falls inside the stated range.
By their numbers in this assay, from the lowest: compound 3; then compounds 1, 4 and 2 (each within the scatter of the next).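

In this assay, among the compounds shown here, the pair formed by these two compounds is the first to isolate this change, and it gives a 1.5-fold lower number from compound 2 to compound 4 (0.19 log units; within the scatter) on going from 2,4-dichlorobenzyl to 2-chlorobenzyl. For the compounds shown here, replacing the chloro para to the large group with hydrogen therefore produces no step that can be told apart from the scatter, which means that in this one pair the number does not depend measurably on that chloro. Nothing available explains this result or says what lies behind it.

The compounds shown leave open whether a methoxy group, an amine or a carboxylic acid in that same place would give a step beyond the scatter. They also leave open what the remaining chloro does, which a plain benzyl group on the same compound would test.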